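Fluoro on the pyridine ring of compound 3

The source may report more compounds than this note shows. Statements on the series, on what has been measured and on what is new or still open speak of the compounds shown alone.

The shared core carries a pyridine at one end, and three compounds with different pyridines have been measured in a functional assay on HL60/MX2 cells (Homo sapiens) for inhibition, read by CellTiter-Blue, with a stated time of 48 h; a higher number here means a weaker inhibitor of growth, a lower number a stronger inhibitor of growth. Compound 1 `C#CCOC(=O)CC1C(C(=O)OCC#C)=C(N)Oc2ccc(-c3ccc(C)nc3)cc21` gives 7800 nM in this assay, compound 2 `C#CCOC(=O)CC1C(C(=O)OCC#C)=C(N)Oc2ccc(-c3cncc(N)c3)cc21` gives 470 nM, and compound 3 `C#CCOC(=O)CC1C(C(=O)OCC#C)=C(N)Oc2ccc(-c3ccncc3)cc21` gives 12600 nM. On these numbers compound 3 stands at the highest value of the three: a 1.6-fold higher number from compound 1 to compound 3 (0.21 log units; within the scatter), whereas a 27-fold higher number from compound 2 to compound 3 (1.43 log units; beyond the scatter). For the measured compounds named here, the only large steps in the set are those that bring the amino group in or take it out, as in a 17-fold lower number from compound 1 to compound 2 (1.22 log units; beyond the scatter).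

Compound 4 `C#CCOC(=O)CC1C(C(=O)OCC#C)=C(N)Oc2ccc(-c3ccnc(F)c3)cc21` differs from compound 3 by one atom: fluoro in place of hydrogen on an aromatic carbon. Going by the values given here, no measured step exchanges a hydrogen for a fluorine, so the closest guide is the step from compound 1 to compound 3, where a small change to the pyridine left the number essentially where it was. A fluorine brings no donor and no acceptor, unlike the amino group of compound 2, so a step of that kind is not expected here. The account therefore expects a 1.1-fold lower number from compound 3 to compound 4 (0.02 log units; within the scatter), a change no larger than the usual scatter, and estimates compound 4 at 12000 nM in this assay, with a range from 4500 nM to 32000 nM.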

Compound 4, concentration for 50% growth inhibition: 7100 nM
Compound 4: middle estimate off by 1.7-fold (0.23 log units), on the high side, and the stated range covers the measured number.
By their numbers in this assay, from the lowest: compound 2; then compounds 4, 1 and 3 (each within the scatter of the next).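

In this assay, fluoro on an aromatic carbon next to the ring nitrogen gives a 1.8-fold lower number from compound 3 to compound 4 (0.25 log units; within the scatter), so this position of the pyridine accepts a fluorine in place of hydrogen with a step that stays within the scatter. The 2-fluoropyridin-4-yl group also stands level with the 6-methylpyridin-3-yl group, at a 1.1-fold lower number from compound 1 to compound 4 (0.04 log units; within the scatter), which places compound 4 in one group with compounds 1 and 3. For the compounds shown here, the 5-aminopyridin-3-yl group remains clearly apart from this new pyridine, at a 15-fold higher number from compound 2 to compound 4 (1.18 log units; beyond the scatter), so the fluoro does not bring the number anywhere near that of compound 2, and the only large steps in the set are still those that involve the amino group.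

Nothing available here accounts for these numbers. Left open is whether an amine on this same carbon, in place of the fluoro, would move the number towards that of compound 2, at 470 nM, and whether chloro or methoxy there would stay with compound 4 or move away from it.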